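Amide substituent variation in a dopamine receptor agonist series

The source may report more compounds than this note shows. Statements on the series, on what has been measured and on what is new or still open speak of the compounds shown alone.

Going by the values given here, compound 3 `O=C(CN1CCC(c2cccc[n+]2[O-])CC1)Nc1ccc(F)cc1` gives 85 nM in a functional assay on HEK293 cells for agonist activity at D(4) dopamine receptor (Homo sapiens), read by FLIPR (on this read-out lower numbers stand for an effect already at smaller amounts and higher numbers for an effect only at larger amounts of compound), the lowest of the three numbers so far. Compound 1 `CSc1cccc(NC(=O)CN2CCC(c3cccc[n+]3[O-])CC2)c1` gives 100 nM, and the difference a 1.2-fold lower number from compound 1 to compound 3 (0.07 log units; within the scatter) stays within the scatter. Compound 2 `O=C(CN1CCC(c2cccc[n+]2[O-])CC1)NC1CCCCC1` gives 294 nM; the step of a 3.5-fold lower number from compound 2 to compound 3 (0.54 log units; beyond the scatter) lies beyond the scatter, as does a 2.9-fold higher number from compound 1 to compound 2 (0.47 log units; beyond the scatter). Compound 4 `O=C(CN1CCC(c2cccc[n+]2[O-])CC1)Nc1cc(Cl)cc(Cl)c1` is not yet measured and differs from compound 3 in one place: 3,5-dichlorophenyl in place of 4-fluorophenyl on an amide-type nitrogen. The step that bears most on it is the aryl-for-aryl exchange a 1.2-fold lower number from compound 1 to compound 3 (0.07 log units; within the scatter), which remained within the scatter; both beyond-scatter steps involve cyclohexyl, which compound 4 does not carry. In this assay compound 4 is therefore expected to show no step beyond the scatter, estimated at 90 nM with a range of 35 nM to 240 nM. The expected step is a 1.1-fold higher number from compound 3 to compound 4 (0.02 log units; within the scatter).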

Compound 4, half-maximal effective concentration: 160 nM
Beside the measured number, compound 4's estimate is 1.8-fold (0.25 log units) below it, within the range that was stated.
By their numbers in this assay, from the lowest: compounds 3, 1, 4 and 2 (each within the scatter of the next, the first and the last beyond it).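

On the amide-type nitrogen, 3,5-dichlorophenyl in place of 4-fluorophenyl stays within the scatter in this assay (a 1.9-fold higher number from compound 3 to compound 4 (0.27 log units; within the scatter)), as does 3,5-dichlorophenyl in place of 3-(methylsulfanyl)phenyl (a 1.6-fold higher number from compound 1 to compound 4 (0.20 log units; within the scatter)). Cyclohexyl is no longer set apart from every aryl group: 3,5-dichlorophenyl in its place also stays within the scatter (a 1.8-fold lower number from compound 2 to compound 4 (0.26 log units; within the scatter)), although compound 2 remains beyond the scatter of compound 1 and compound 3. No supporting evidence bears on these steps. Open, going by these compounds, is how an amine, a carboxylic acid or a longer chain on this nitrogen would read against these aryl groups and cyclohexyl.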